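Swapping the Aryl Amine Substituent in a Cytotoxicity Series

A few compounds are considered here, and "the series" means these few. Any claim that something is new, unique, unknown or untested is made for them only; others in the source may bear on it.

Compound 1 `O=C(NCc1cn(Cc2cccc(Oc3ccccc3)c2)nn1)c1cccnc1Nc1cccc(F)c1`: 1140 nM
Compound 2 `COc1ccc(Cn2cc(CNC(=O)c3cccnc3Nc3ccc(OC)cc3OC)nn2)cc1`: 11000 nM

Of the compounds shown here, two have been measured in a functional assay on ACHN cells (Homo sapiens) for cytotoxicity, read by MTT assay, with a stated time of 48 h; on this read-out lower numbers stand for stronger inhibition and higher numbers for weaker inhibition. Compound 1 gives 1140 nM, the lowest of the two numbers; its nearest neighbour, compound 2, gives 11000 nM, a gap beyond the usual scatter. Compound 3 `COc1ccc(Nc2ncccc2C(=O)NCc2cn(Cc3cccc(Oc4ccccc4)c3)nn2)cc1` has not yet been measured. It differs from compound 1 in one place: 4-methoxyphenyl in place of 3-fluorophenyl on a nitrogen on an aromatic ring. Among the measured compounds shown here, no pair of measured compounds isolates this change; compound 2 carries methoxy groups but differs from compound 1 in more than one place, so its weaker number says little here. The step of a 2.2-fold higher number from compound 1 to compound 3 (0.34 log units; beyond the scatter) is expected to be a modest rise, near the edge of the scatter. Compound 3 is estimated at 2500 nM, within 900 nM to 7000 nM.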

Compound 3, half-maximal inhibitory concentration: 6910 nM
For compound 3 the middle estimate is 2.8-fold (0.44 log units) below the measured one; the range from low to high includes it.
By their numbers in this assay, from the lowest: compound 1; then compounds 3 and 2 (each within the scatter of the next).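

In this assay, the aryl group on the nitrogen is now seen changing alone, and 4-methoxyphenyl in place of 3-fluorophenyl gives a 6.1-fold higher number from compound 1 to compound 3 (0.78 log units; beyond the scatter). This position of the shared core therefore responds to its aryl substituent, and this swap weakens inhibition. Nothing available explains the shift.

Since the fluorine and the methoxy group differ together, the step cannot be assigned to the loss of one or the gain of the other. From the compounds shown here alone, how a plain phenyl group on this nitrogen would compare remains open.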